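Fluorine for chlorine on the aryl ether of compound 1

The source may hold more compounds than are shown below. What is called first, only, known or untested is meant among the compounds shown, and "the series" means these compounds.

Compound 1 `N#Cc1ccc(Nc2nc(Oc3ccc(Cl)cc3Cl)c3ccccc3n2)cc1` is one of three compounds examined in an ADME assay on MT4 cells (Homo sapiens) for cytotoxicity, read by MTT assay, with a stated time of 4 days; a higher number here means that more compound is tolerated, a lower number that less compound is tolerated. Compound 1 gives 32000 nM, the lowest of the three numbers. Compound 2 `Cc1cccc(C)c1Oc1nc(Nc2ccc(C#N)cc2)nc2ccccc12` gives 35000 nM, and the difference a 1.1-fold higher number from compound 1 to compound 2 (0.04 log units; within the scatter) is within the scatter. Compound 3 `N#Cc1ccc(Nc2nc(Oc3ccc(Cl)cc3)c3ccccc3n2)cc1` gives 198000 nM, the furthest from compound 1, with a 6.2-fold higher number from compound 1 to compound 3 (0.79 log units; beyond the scatter).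

Compound 4 `N#Cc1ccc(Nc2nc(Oc3ccc(F)cc3)c3ccccc3n2)cc1` differs from compound 1 at the aryl ether: 4-fluorophenyl in place of 2,4-dichlorophenyl on an oxygen on an aromatic ring. The nearest comparison is the step of a 6.2-fold higher number from compound 1 to compound 3 (0.79 log units; beyond the scatter), where one chloro was removed from the same ring, and the step of a 5.7-fold higher number from compound 2 to compound 3 (0.75 log units; beyond the scatter) points the same way. Both steps went to a higher number once the ring carried a single halogen at one position. Compound 4 also carries a single halogen there, a fluorine instead of chlorine. A step upward beyond the scatter is therefore expected, of about a 6.3-fold higher number from compound 1 to compound 4 (0.80 log units; beyond the scatter), with uncertainty about whether fluorine and chlorine behave alike. The estimated value for compound 4 in this assay is 200000 nM, with a range from 70000 nM to 500000 nM.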

Compound 4, half-maximal cytotoxic concentration: > 351000 nM
Compound 4: a limit, no number (the forecaster's own chance of this, stated with the estimate: 20%); at least 1.7-fold (0.24 log units) between middle value and limit.
By their numbers in this assay, from the lowest: compounds 1 and 2 (each within the scatter of the next); then compound 3. At a limit, above all of these: compound 4.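

In this assay, compound 4 gives a limit and not a number: the limit of > 351000 nM in this assay, at which 1 of the 4 values shown sits. Replacing the aryl ether group of compound 1 or compound 2 with 4-fluorophenyl produces the largest changes seen so far in this small set, with an at least 10-fold higher number from compound 1 to compound 4 (1.04 log units; beyond the scatter) and an at least 10-fold higher number from compound 2 to compound 4 (1.00 log units; beyond the scatter). Going by these compounds alone, the closest comparison changes only the halogen, giving an at least 1.7-fold higher number from compound 3 to compound 4 (0.24 log units; that floor lies within the scatter), so this is the first view of fluoro in place of chloro at this position, but the floor of that step lies within the scatter and does not show that the two halogens truly differ.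

The limit leaves the real number for compound 4 unknown, and with it the full size of all three steps. As far as these compounds go, whether an amine or a methoxy group on the same ring would give a similar reading also remains open.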